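Moving the fluorine around the phenyl ring of a piperazine amide

The compounds below may be only part of what the source reports. "The series", "measured", "known", "first", "only" and "open" are said of these compounds alone.

Measured compounds:
Compound 1, `CCC(C(=O)N1CCN(c2cccc(F)c2)CC1)N1C(=O)CCC1=O`, gives 100%.
Compound 2, `CC(C(=O)N1CCN(c2ccccc2F)CC1)N1C(=O)CCC1=O`, gives 50%.
Compound 3, `CCC(C(=O)N1CCN(c2ccc(F)cc2)CC1)N1C(=O)CCC1=O`, gives 25%.

These three values come from a functional assay on the whole organism (strain Swiss) with Mus musculus as the target, in the maximal electroshock model, with a stated time of 0.5 h, at a dose of 300 mg/kg by the intraperitoneal route; a lower number here means a weaker effect, a higher number a stronger effect of the compound at the dose given. Compound 3 stands lowest of the three: compound 2 lies closest, with a value one step above it, and compound 1 stands furthest away, at the top of the set. Among the measured compounds shown here, the one measured step that changes a single place is a number 75 percentage points lower from compound 1 to compound 3 (beyond the scatter), a large drop for nothing more than a shift of the fluorine on the phenyl ring.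

Compound 4, `CCC(C(=O)N1CCN(c2ccccc2F)CC1)N1C(=O)CCC1=O`, is not yet measured. It differs from compound 3 by 2-fluorophenyl in place of 4-fluorophenyl on an amine nitrogen in a ring. For the measured compounds named here, the only step that bears on this change is the one from compound 1 to compound 3, which shows that the position of the fluorine can move the read-out across most of its range. Going by the values given here, compound 2 carries the 2-fluorophenyl group too and sits above compound 3, though it also differs in the chain, so no step between them is counted. On this basis compound 4 is expected to rise above compound 3, with an estimated step of a number 35 percentage points higher from compound 3 to compound 4 (beyond the scatter). Compound 4 is therefore estimated at 60%, within a range from 25% to 100%.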

Compound 4, a percentage reported as activity, at one dose (the size of the read-out at that dose, not a potency): 100%
Compound 4: the middle estimate sits 40 percentage points below what was measured; the measured number falls inside the stated range.
By their numbers in this assay, from the lowest: compound 3; then compound 2; then compounds 1 and 4 (each within the scatter of the next).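

In this assay, the 2-fluorophenyl and 4-fluorophenyl groups are far from interchangeable on the amine nitrogen in a ring, as a number 75 percentage points higher from compound 3 to compound 4 (beyond the scatter) shows, so the low value belongs to the 4-fluorophenyl compound alone among the three fluorine positions on this chain. The 2-fluorophenyl and 3-fluorophenyl groups cannot be told apart, with no change at the digits printed from compound 1 to compound 4 (within the scatter). Among the compounds shown here, the chain matters as well, which the earlier compounds could not show: with the 2-fluorophenyl group held fixed, methyl in place of hydrogen on the saturated chain carbon gives a number 50 percentage points higher from compound 2 to compound 4 (beyond the scatter).

Nothing available explains why these positions or the chain carbon differ in this way. The compounds shown leave open whether chlorine or methoxy could replace the fluorine and whether a longer chain would keep the read-out, and a single dose cannot rank compound 1 and compound 4 by potency.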